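Swapping the thiophene for a pyrimidine on the amidine carbon

The compounds below may be only part of what the source reports. "The series", "measured", "known", "first", "only" and "open" are said of these compounds alone.

The three measured compounds share one core and differ only in the aromatic group on the carbon with a double bond to nitrogen. Compound 1 `Fc1ccc(C2(c3ccc(F)cc3)CNC(c3cccc(Cl)c3)=N2)cc1` gives 5.4 nM in an assay on LM cells for displacement of a labelled ligand from Neuropeptide Y receptor type 5 (Homo sapiens) (a lower number here means a stronger inhibitor, a higher number a weaker inhibitor), and compound 2 `N#Cc1cccc(C2=NC(c3ccc(F)cc3)(c3ccc(F)cc3)CN2)c1` gives 2.7 nM. Compound 3 `Fc1ccc(C2(c3ccc(F)cc3)CNC(c3ccsc3)=N2)cc1` gives 93 nM, the highest number of the three, so it is the weakest inhibitor shown. The steps leading to it are large: a 17-fold higher number from compound 1 to compound 3 (1.24 log units; beyond the scatter) and a 34-fold higher number from compound 2 to compound 3 (1.54 log units; beyond the scatter). The step from the chloro to the cyano substituent, a 2.0-fold lower number from compound 1 to compound 2 (0.30 log units; within the scatter), is within the scatter.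

Compound 4 `Fc1ccc(C2(c3ccc(F)cc3)CNC(c3cncnc3)=N2)cc1` is not yet measured. It differs from compound 3 in one place: pyrimidin-5-yl in place of thiophen-3-yl on a carbon with a double bond to nitrogen. For the measured compounds named here, no measured step involves a pyrimidinyl group, so the two large steps above bear on it only indirectly, as they show how much the thiophen-3-yl group costs against substituted phenyl rings. The pyrimidinyl ring is closer in kind to those phenyl rings than to the thiophene, so some recovery is expected, though the missing substituent leaves this uncertain. For compound 4 the expected step is a 3.7-fold lower number from compound 3 to compound 4 (0.57 log units; beyond the scatter), giving an estimated value of 25 nM, ranging from 5 nM to 120 nM.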

Compound 4, half-maximal inhibitory concentration: 47 nM
Beside the measured number, compound 4's estimate is 1.9-fold (0.27 log units) below it, within the range that was stated.
By their numbers in this assay, from the lowest: compounds 2 and 1 (each within the scatter of the next); then compounds 4 and 3 (each within the scatter of the next).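

In this assay, replacing the five-membered thiophen-3-yl ring with the six-membered pyrimidin-5-yl ring makes no clear difference (a 2.0-fold lower number from compound 3 to compound 4 (0.30 log units; within the scatter)), so ring size and the count of ring hetero atoms, as varied in this one change, do not separate these two compounds. Compound 4 still sits well away from the substituted phenyl compounds, with a modest gap to one (an 8.7-fold higher number from compound 1 to compound 4 (0.94 log units; beyond the scatter)) and a large gap to the other (a 17-fold higher number from compound 2 to compound 4 (1.24 log units; beyond the scatter)), so among these four compounds, both rings without a chloro or cyano substituent give clearly higher numbers than both rings that carry one, and none of the four goes against this. Nothing available explains why this position responds in this way.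

These compounds leave open whether the gap follows the chloro or cyano substituent or the hetero atoms in the ring, since every comparison with a substituted phenyl ring changes both at once. A plain phenyl ring, or a pyrimidin-5-yl ring carrying a chloro or a nitrile, would help to tell these two apart.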